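Amine Variation at the Thiocarbonyl in an Antiproliferative Series

This account rests on a few compounds, and the source may have more. Where it says the series, first, only, none or still open, it means among the compounds named here.

Compound 1 `Nc1ccccc1NC(=O)c1ccc(CSC(=S)N2CCN(C3CCCCC3)CC2)cc1`: 16.9%
Compound 2 `CC1CCCCN1C(=S)SCc1ccc(C(=O)Nc2ccccc2N)cc1`: 64.4%
Compound 3 `Nc1ccccc1NC(=O)c1ccc(CSC(=S)N2CCc3ccc([N+](=O)[O-])cc32)cc1`: 30.6%

The three measured compounds share one core and differ only in the amine attached to the thiocarbonyl carbon. In a functional assay on MGC-803 cells (Homo sapiens) for antiproliferative activity, read by CCK-8 assay, with a stated time of 72 h, tested at 2 uM (on this read-out higher numbers stand for a stronger effect at the one concentration tested and lower numbers for a weaker effect), compound 2 gives 64.4%, the highest of the three numbers. Compound 3 gives 30.6%, a number beyond the scatter below it, and compound 1 gives 16.9%, further below still. Compound 2 thus stands clearly apart from the other two on this read-out.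

Compound 4 `Nc1ccccc1NC(=O)c1ccc(CSC(=S)N2CCCC2)cc1` has not yet been measured. Relative to compound 2 its change is pyrrolidin-1-yl in place of 2-methylpiperidin-1-yl on a thiocarbonyl carbon. Going by the values given here, no step between two measured compounds matches this change, so the expectation rests on the spread alone: both other amines at this place fall well short of compound 2, and a smaller ring without the methyl is taken here as more likely to lower than to raise the number. The expected step from compound 2 to compound 4 is downward and of a size that could exceed the scatter, a number 22.4 percentage points lower from compound 2 to compound 4 (beyond the scatter). Compound 4 is accordingly estimated to give 42%, with a range from 18% to 66%.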

Compound 4, a percentage reported as inhibition, at one concentration (the size of the read-out at that concentration, not a potency): 27%
Compound 4: the middle estimate sits 15 percentage points above what was measured; low and high end bracket the measured number.
By their numbers in this assay, from the lowest: compound 1; then compounds 4 and 3 (each within the scatter of the next); then compound 2.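

In this assay, going by these compounds alone, the change from 2-methylpiperidin-1-yl to pyrrolidin-1-yl on a thiocarbonyl carbon gives the first readable step at this position, a number 37.4 percentage points lower from compound 2 to compound 4 (beyond the scatter), and the step is large. The earlier compounds shown here showed only that three quite different amines gave different numbers, whereas this pair shows that a change between two simple non-aromatic rings, each with one hetero atom, is enough to lose much of the effect seen with compound 2. The high number therefore does not extend to every small non-aromatic ring amine among the compounds shown: compound 4, at 27%, lies within the scatter of compound 3, at 30.6%, and compound 2 remains apart from both.

No available measurement bears on the reason for this drop. Piperidin-1-yl without the methyl, or 2-methylpyrrolidin-1-yl, would separate the ring size from the methyl group, and the compounds shown leave open which of the two carries the step.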